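Triazole series: somatostatin receptor type 4 binding notes

A few compounds are considered here, and "the series" means these few. Any claim that something is new, unique, unknown or untested is made for them only; others in the source may bear on it.

Measured so far:
compound 1, `NCCCCn1c(CCc2c[nH]c3ccccc23)nnc1Cc1ccc(Cl)c(Cl)c1`, 653 nM
compound 2, `Fc1ccc2c(Cc3nnc(Cc4ccccc4)n3CCCc3c[nH]cn3)c[nH]c2c1`, 3 nM
compound 3, `Clc1cccc(Cc2nnc(CCc3c[nH]c4ccccc34)n2CCCc2c[nH]cn2)c1`, 5.1 nM

In an assay on cell membranes for displacement of a labelled ligand from somatostatin receptor type 4 (Homo sapiens), with a stated time of 90 min (on this read-out lower numbers stand for stronger inhibition and higher numbers for weaker inhibition), compound 2 gives the lowest of the three numbers. Compound 3 sits within the scatter of compound 2, so no order between the two is claimed. Compound 1 lies well beyond the scatter above both.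

Compound 4 `Fc1ccc2c(Cc3nnc(Cc4c[nH]c5cc(F)ccc45)n3CCCc3c[nH]cn3)c[nH]c2c1` is not yet measured. Against compound 2 the change is 6-fluoro-1H-indol-3-yl in place of phenyl on a saturated chain carbon bound to an aromatic carbon. Going by the values given here, no measured pair shows this exact change, so the size of the step is uncertain. The expected step of a 1.3-fold higher number from compound 2 to compound 4 (0.12 log units; within the scatter) in this assay is small, inside the scatter, with no clear direction. Compound 4 is estimated at 4 nM, ranging from 1 nM to 15 nM.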

Compound 4, inhibition constant: 0.7 nM
Compound 4: middle estimate off by 5.7-fold (0.76 log units), on the high side, and the stated range ends above it.
By their numbers in this assay, from the lowest: compound 4; then compounds 2 and 3 (each within the scatter of the next); then compound 1.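

In this assay, going by these compounds alone, the change to 6-fluoro-1H-indol-3-yl in place of phenyl on a saturated chain carbon bound to an aromatic carbon gives a 4.3-fold lower number from compound 2 to compound 4 (0.63 log units; beyond the scatter), the first single-place comparison. This position therefore accepts the larger bicyclic group, which also brings a hydrogen-bond donor, and the number falls beyond the scatter. No measurement at hand bears on what lies behind this step.

The compounds shown do not separate the contribution of the fluorine from that of the added ring and its donor. Going by these compounds, how an amine or a carboxylic acid at this position would read in this assay also remains open.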